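A Cyano Group in Place of Pyridinyl: Solubility Outlook

The source may hold more compounds than are shown below. What is called first, only, known or untested is meant among the compounds shown, and "the series" means these compounds.

Measured compounds:
compound 1 `Cc1noc(-c2nc(C)c3c(c2N)C(=O)N(Cc2ccccc2)C3=O)n1` — < 5000 nM
compound 2 `Cc1noc(-c2nc(C)c3c(c2N)C(=O)N(Cc2ccc(-c4ccncc4)cc2)C3=O)n1` — < 5000 nM
compound 3 `Cc1noc(-c2nc(C)c3c(c2N)C(=O)N(Cc2cccc(F)c2)C3=O)n1` — < 5000 nM

In a physicochemical assay for solubility, using the shake flask method, in simulated intestinal fluid, measured as kinetic solubility, with a stated time of 2 h, at 25 degrees C, at pH 6.5 (a higher number here means a more soluble compound, a lower number a less soluble compound), compound 1 gives < 5000 nM, which is a limit of the assay rather than a number. Compound 2 likewise gives < 5000 nM, again a limit. Compound 3 gives < 5000 nM, also a limit. Compound 2 thus stands at the same limit as every other value shown, since all three sit there (the limit of < 5000 nM in this assay, at which 3 of the 3 values shown sit). For that reason the step that the two limits leave unreadable from compound 1 to compound 2 and the step that the two limits leave unreadable from compound 1 to compound 3 cannot be read in size or direction.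

Compound 4 `Cc1noc(-c2nc(C)c3c(c2N)C(=O)N(Cc2ccc(C#N)cc2)C3=O)n1` differs from compound 2 by cyano in place of pyridin-4-yl on an aromatic carbon. Among the compounds with values here, no measured step bears on this change in a readable way, and the three limits give no direction to build on. Compound 4 is therefore expected to remain near the same limit, with a step that the limit leaves unreadable from compound 2 to compound 4 estimated as no step beyond the scatter. The estimate for compound 4 is 2500 nM, expected to lie between 500 nM and 8000 nM.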

Compound 4, solubility: < 5000 nM
Compound 4 gave a limit, no number; the forecaster's own chance of this, stated with the estimate: 75%; the middle value lies beyond the limit too.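

Compound 4 gives < 5000 nM, a limit of the assay, so its steps from compound 1, compound 2 and compound 3 cannot be read: the limit of < 5000 nM in this assay, at which 4 of the 4 values shown sit. The compounds shown leave open where any of them actually lies in this assay, and whether cyano, fluoro or pyridin-4-yl makes any difference there.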